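Swapping a benzyl for a chlorophenoxy on the shared core

This account rests on a few compounds, and the source may have more. Where it says the series, first, only, none or still open, it means among the compounds named here.

Compound 1 `c1ccc(Cc2ccc3c(NCCCNCc4ccco4)ccnc3c2)cc1`: 16000 nM
Compound 2 `COc1ccc(F)cc1CNCCCNc1ccnc2cc(Cc3ccccc3)ccc12`: 7990 nM

Going by the values given here, in an ADME assay on HepG2 cells (Homo sapiens) for cytotoxicity, read by luminescence, CellTiter-Glo and ATP content, with a stated time of 72 h (on this read-out lower numbers stand for an effect already at smaller amounts and higher numbers for an effect only at larger amounts of compound), compound 2 gives the lowest of the two numbers, yet its only neighbour, compound 1, sits a 2.0-fold lower number from compound 1 to compound 2 (0.30 log units; within the scatter) away, so the two cannot be ordered. Compound 3 `COc1ccc(F)cc1CNCCCNc1ccnc2cc(Oc3ccc(Cl)cc3)ccc12` is built from compound 2 by 4-chlorophenoxy in place of benzyl on an aromatic carbon. Among the compounds with values here, no measured step touches this position; the single known step concerns a different part of the molecule and was within the scatter. With nothing pointing either way, the expected step of a 1.0-fold higher number from compound 2 to compound 3 (0.00 log units; within the scatter) is none beyond the scatter. Compound 3 is therefore estimated at 8000 nM, within 2500 nM to 25000 nM.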

Compound 3, half-maximal effective concentration: 4500 nM
Estimate against measurement, compound 3: 1.8-fold (0.25 log units) above; the measured number falls inside the stated range.
By their numbers in this assay, from the lowest: compounds 3, 2 and 1 (each within the scatter of the next, the first and the last beyond it).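

Going by these compounds alone, this is the first measured change on this aromatic carbon of the shared core. In this assay, 4-chlorophenoxy in place of benzyl gives a 1.8-fold lower number from compound 2 to compound 3 (0.25 log units; within the scatter), so the swap of a carbon link for an oxygen link, with a chlorine added on the ring, produces no step beyond the scatter. No measured evidence here offers a reason for this result. Still open, as far as these compounds go, is whether an amine or a carboxylic acid on this same carbon would produce a step beyond the scatter. Also open, from the compounds shown here alone, is whether 4-chlorophenoxy would behave alike with furan-2-yl on the chain.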